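A Fluorophenyl Swap on the Ring Nitrogen

A few compounds are considered here, and "the series" means these few. Any claim that something is new, unique, unknown or untested is made for them only; others in the source may bear on it.

Of the compounds shown here, three built on one shared core have been measured in a functional assay on A549 cells (Homo sapiens) for antiproliferative activity, read by MTT assay, with a stated time of 24 h; a lower number here means a stronger inhibitor, a higher number a weaker inhibitor. Compound 1 `O=c1[nH]cc(S(=O)(=O)Nc2ccccc2-c2cn(-c3cccc(F)c3)nn2)c(=O)[nH]1` gives 8130 nM, compound 2 `O=c1[nH]cc(S(=O)(=O)Nc2ccccc2-c2cn(-c3ccc(Cl)cc3)nn2)c(=O)[nH]1` gives 1180 nM, and compound 3 `Cc1ccccc1-n1cc(-c2cccc(NS(=O)(=O)c3c[nH]c(=O)[nH]c3=O)c2)nn1` gives 5470 nM. Compound 3 thus holds the second highest of the three numbers: it sits within the scatter of compound 1, while compound 2 lies a clear step away. Among the compounds with values here, the only single-point step among the measured set, a 6.9-fold lower number from compound 1 to compound 2 (0.84 log units; beyond the scatter), concerns an exchange of the aryl group on the ring nitrogen, and a change of the same kind separates compound 3 from the unmeasured compound 4 `O=c1[nH]cc(S(=O)(=O)Nc2cccc(-c3cn(-c4ccc(F)cc4)nn3)c2)c(=O)[nH]1`: 4-fluorophenyl in place of 2-methylphenyl on an aromatic nitrogen. The two changes are not the same, however. Within the data shown here, the remainder of compound 4 is not identical to that of compounds 1 and 2, and no measured pair shows a methyl giving way to a fluorine on this aryl group. Among the measured compounds shown here, a shift as large as the one from compound 1 to compound 2 therefore cannot be assumed. One expects only a small step, a 1.6-fold lower number from compound 3 to compound 4 (0.19 log units; within the scatter), toward a lower number. Compound 4 is estimated at 3500 nM, with a range from 1200 nM to 10000 nM.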

Compound 4, half-maximal inhibitory concentration: > 20000 nM
Compound 4 ended at the assay's limit; the forecaster's own chance of this, stated with the estimate: 5%; middle value at least 5.7-fold (0.75 log units) away from the limit.
By their numbers in this assay, from the lowest: compound 2; then compounds 3 and 1 (each within the scatter of the next). At a limit, above all of these: compound 4.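

Within the data shown here, this position is not one where an aryl exchange only lowers the number: the one earlier step, a 6.9-fold lower number from compound 1 to compound 2 (0.84 log units; beyond the scatter), ran downward, whereas 4-fluorophenyl in place of 2-methylphenyl gives an at least 3.6-fold higher number from compound 3 to compound 4 (0.56 log units; beyond the scatter) in this assay. The two groups match in heavy-atom count, in their single carbon-only aromatic ring and in hydrogen-bond donors and acceptors, so an exchange that leaves all of these counts unchanged is still enough to produce a step beyond the scatter. Compound 4 gives > 20000 nM, which is a limit of the assay and not a number, so the step has a lower bound but no known full size: the limit of > 20000 nM in this assay, at which 1 of the 4 values shown sits.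

The compounds shown do not separate the loss of the methyl from the gain of the fluorine, and they do not show whether 4-chlorophenyl would give compound 4's frame a lower number as it does in the step to compound 2. They also leave open how this position would respond to an aryl group carrying an amine or a carboxylic acid, or to a longer alkyl chain in place of the aryl group.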